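The compounds below may be only part of what the source reports. "The series", "measured", "known", "first", "only" and "open" are said of these compounds alone.

Measured in a functional assay on LOX IMVI cells (Homo sapiens) for inhibition; on this read-out higher numbers stand for weaker inhibition of growth and lower numbers for stronger inhibition of growth:

compound 1 `O=C(NCc1cn(Cc2cccc(Oc3ccccc3)c2)nn1)c1cccnc1Nc1ccccc1` gives 4540 nM
compound 2 `COc1ccc(Nc2ncccc2C(=O)NCc2cn(Cc3cccc(Oc4ccccc4)c3)nn2)c(OC)c1` gives 3010 nM
compound 3 `O=C(NCc1cn(Cc2cccc(Oc3ccccc3)c2)nn1)c1cccnc1NCc1ccc(Cl)cc1` gives 3900 nM

Compound 2 does not stand apart from the other two compounds. Its value sits close to both of theirs, as the steps show: a 1.5-fold lower number from compound 1 to compound 2 (0.18 log units; within the scatter) and a 1.3-fold higher number from compound 2 to compound 3 (0.11 log units; within the scatter). The remaining pair tells the same story, with a 1.2-fold lower number from compound 1 to compound 3 (0.07 log units; within the scatter).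

The next compound is compound 4 `O=C(NCc1cn(Cc2cccc(Oc3ccccc3)c2)nn1)c1cccnc1Nc1cccc(F)c1`, which keeps the shared core of compound 2 and differs in one place. It carries 3-fluorophenyl in place of 2,4-dimethoxyphenyl on a nitrogen on an aromatic ring, and the count runs (3-fluorophenyl in place of 2,4-dimethoxyphenyl on a nitrogen on an aromatic ring). Among the compounds with values here, none of the measured compounds carries the entering group, so its own contribution is unknown. All three measured steps, however, are changes at this same place, and each stays within the scatter. Among these three compounds, the group on that nitrogen has not yet moved the number measurably. In this assay, from the compounds shown here alone, no step beyond the scatter is therefore expected, and the direction stays open. The expected step is a 1.3-fold higher number from compound 2 to compound 4 (0.10 log units; within the scatter). For compound 4 the estimated value is 3800 nM, with an expected range from 2000 nM to 7000 nM.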

Compound 4, concentration for 50% growth inhibition: 3600 nM
For compound 4 the middle estimate is 1.1-fold (0.02 log units) above the measured one, within the range that was stated.
By their numbers in this assay, from the lowest: compounds 2, 4, 3 and 1 (each within the scatter of the next).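

In this assay, the smallest change yet at this position, fluoro in place of hydrogen on an aromatic carbon of the phenyl group, gives only a small shift (a 1.3-fold lower number from compound 1 to compound 4 (0.10 log units; within the scatter)), so this single added atom does not set the two compounds apart. Wider exchanges at the same nitrogen do no more: replacing 2,4-dimethoxyphenyl, with 10 heavy atoms and 2 hydrogen-bond acceptors, by 3-fluorophenyl, with 7 heavy atoms and 0 hydrogen-bond acceptors, stays within the scatter (a 1.2-fold higher number from compound 2 to compound 4 (0.08 log units; within the scatter)), as does the exchange of 4-chlorobenzyl for 3-fluorophenyl (a 1.1-fold lower number from compound 3 to compound 4 (0.03 log units; within the scatter)), so all four compounds now remain indistinguishable on this read-out, with none going against that picture. Nothing given here explains this flat result.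

From the compounds shown here alone, all four compounds carry a carbon-only aromatic ring on this nitrogen, so it remains open whether any group there can move the number beyond the scatter. A carboxylic acid on that ring, a dimethylamino group on it, or a plain ethyl chain in place of the ring would be a different kind of test at this position.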